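Stilbene-type fluorostilbenes: a third fluorine on compound 3

The compounds below may be only part of what the source reports. "The series", "measured", "known", "first", "only" and "open" are said of these compounds alone.

Measured compounds:
- compound 1 `Fc1ccccc1/C=C/c1ccccc1`: in an assay on HepG2 cells for activation of nuclear factor erythroid 2-related factor 2 (Homo sapiens), read by a luciferase reporter, with a stated time of 5 h (on this read-out lower numbers stand for an effect already at smaller amounts and higher numbers for an effect only at larger amounts of compound), compound 1 gives 700 nM.
- compound 2 `Fc1ccc(/C=C/c2ccccc2F)cc1F`: in this assay compound 2 gives only the limit > 15000 nM.
- compound 3 `Fc1cccc(/C=C/c2ccccc2F)c1`: in this assay compound 3 gives only the limit > 15000 nM.

Compound 3 stands at the limit of this assay and not at a number; the same holds for compound 2, so that two of the three values shown sit at the limit (the limit of > 15000 nM in this assay, at which 2 of the 3 values shown sit), and only compound 1 has a read number.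

The unmeasured compound 4 `Fc1cccc(/C=C/c2cc(F)ccc2F)c1` differs from compound 3 by fluoro in place of hydrogen on an aromatic carbon.

Within the data shown here, two measured steps concern this kind of change. The step of an at least 21-fold higher number from compound 1 to compound 3 (1.33 log units; beyond the scatter) shows that adding a fluoro pushed the value out of the readable range. The step that the two limits leave unreadable from compound 2 to compound 3 cannot be read, because both ends sit at the limit (the limit of > 15000 nM in this assay, at which 2 of the 3 values shown sit). Compound 4 thus starts from a compound already at the limit and adds a further fluoro; the one readable step in this direction was large and unfavourable, and nothing in the shown compounds points back toward smaller numbers.

Compound 4 is therefore expected to remain at or beyond the limit of this assay, the estimated step being a step that the limit leaves unreadable from compound 3 to compound 4. The estimate for compound 4 is 25000 nM, within a range of 8000 nM to 80000 nM, most likely reported again only as a limit.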

Compound 4, half-maximal effective concentration: 300 nM
Compound 4: middle estimate off by 83-fold (1.92 log units), on the high side, and the stated range ends above it.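

On the shared core, fluoro in place of hydrogen on an aromatic carbon has no single direction. At the place on compound 4, para to a fluoro group and meta to a group of 9 heavy atoms, this assay records an at least 50-fold lower number from compound 3 to compound 4 (1.69 log units; beyond the scatter), whereas the same kind of change elsewhere on the core gave an at least 21-fold higher number from compound 1 to compound 3 (1.33 log units; beyond the scatter), so the outcome of this change depends on where the fluoro enters, at least across these compounds. The limit reached by compound 3 therefore does not close off this substitution pattern, since one further fluoro returns the series to a read number, though the size of that return is only a bound, its starting point being a limit and not a number: the limit of > 15000 nM in this assay, at which 2 of the 4 values shown sit.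

As far as these compounds go, whether the new fluoro would have the same effect on compound 1, without the fluoro that compound 3 carries on the other ring, remains open, and so does how far the result depends on that fluoro being present. Also open, from the compounds shown here alone, is whether this place tolerates anything other than fluoro, such as an amine, a methoxy group or a carboxylic acid.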